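Chloro to Methyl on the Phenylamino Group of Compound 1

The source may report more compounds than this note shows. Statements on the series, on what has been measured and on what is new or still open speak of the compounds shown alone.

Compound 1 `CC(C)c1ccc(-c2nc(SCc3cn(CC(=O)NC(=O)Nc4ccccn4)nn3)nc(Nc3cccc(Cl)c3)c2C#N)cc1` in a functional assay on MGC-803 cells (Homo sapiens) for inhibition, read by MTT assay, with a stated time of 72 h (a higher number here means a weaker inhibitor, a lower number a stronger inhibitor), is reported only as the limit > 64000 nM.
Compound 2 `CC(C)c1ccc(-c2nc(SCc3cn(CC(=O)NC(=O)Nc4ccccn4)nn3)nc(Nc3cccc([N+](=O)[O-])c3)c2C#N)cc1` in this assay is likewise reported only as the limit > 64000 nM.
Compound 3 `Cc1ccccc1Nc1nc(SCc2cn(CC(=O)NC(=O)Nc3ccccn3)nn2)nc(-c2ccc(C(C)C)cc2)c1C#N` in this assay gives 19000 nM.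

Compound 1 therefore stands at the assay limit, where two of the three measured values sit (the limit of > 64000 nM in this assay, at which 2 of the 3 values shown sit). Compound 4 `Cc1cccc(Nc2nc(SCc3cn(CC(=O)NC(=O)Nc4ccccn4)nn3)nc(-c3ccc(C(C)C)cc3)c2C#N)c1` differs from compound 1 by methyl in place of chloro on an aromatic carbon. Going by the values given here, the only measured steps that bear on it are those leaving the same phenylamino position: an at least 3.3-fold lower number from compound 1 to compound 3 (0.52 log units; beyond the scatter) and an at least 3.3-fold lower number from compound 2 to compound 3 (0.52 log units; beyond the scatter), both of which moved from a limit to a readable number when a methyl-bearing phenyl replaced a chloro- or nitro-bearing one. Going by these compounds, a methyl at the 3-position of the phenyl is untested, so compound 4 is expected to give a smaller number than compound 1, estimated at 40000 nM (range 15000 nM to 100000 nM), a step of an at least 1.6-fold lower number from compound 1 to compound 4 (0.20 log units; that floor lies within the scatter).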

Compound 4, half-maximal inhibitory concentration: 25300 nM
Beside the measured number, compound 4's estimate is 1.6-fold (0.20 log units) above it, and the stated range covers the measured number.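

In this assay, methyl at the place of the earlier substituents gives an at least 2.5-fold lower number from compound 1 to compound 4 (0.40 log units; beyond the scatter), and in place of nitro it gives an at least 2.5-fold lower number from compound 2 to compound 4 (0.40 log units; beyond the scatter), so a readable number does not require the 2-methylphenyl group of compound 3. The two methylphenyl groups cannot be told apart, with a 1.3-fold higher number from compound 3 to compound 4 (0.12 log units; within the scatter). Compound 1 and compound 2 remain limits of the assay: the limit of > 64000 nM in this assay, at which 2 of the 4 values shown sit.

Going by these compounds, the step between chloro and nitro cannot be read, and the true sizes of the steps from those limits remain unknown. On these data alone, whether methoxy, ethyl or an amine at this place would also give a readable number remains open.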